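Aryl amides of a diacetylated biphenyl core in the writhing test

The source may report more compounds than this note shows. Statements on the series, on what has been measured and on what is new or still open speak of the compounds shown alone.

Measured so far:
compound 1 `CNC(=O)c1cc(-c2ccc(F)cc2F)ccc1OC(C)=O` — 29.9%
compound 2 `CC(=O)Oc1ccc(-c2ccc(F)cc2F)cc1C(=O)NCc1ccccc1` — 16.6%
compound 3 `CC(=O)Oc1ccc(-c2ccc(F)cc2F)cc1C(=O)Nc1ccccc1Cl` — 11.7%

Three compounds share one core and differ only in the group on the amide-type nitrogen. In a functional assay on the whole organism (strain Kunming) for inhibition, with Mus musculus as the target, in the writhing test, at a dose of 40 mg/kg by the oral route (on this read-out higher numbers stand for more inhibition at the one dose given (going by the name of the read-out) and lower numbers for less inhibition), compound 1 gives 29.9%, the highest of the three. Compound 2 stands second; its step to compound 3 lies within the scatter, while compound 1 sits clearly higher, as a number 13.3 percentage points lower from compound 1 to compound 2 (beyond the scatter) shows. The step of a number 18.2 percentage points lower from compound 1 to compound 3 (beyond the scatter) is of the same kind. The step of a number 4.9 percentage points lower from compound 2 to compound 3 (within the scatter) shows that moving from benzyl to a substituted phenyl on that nitrogen changed little.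

Compound 4 `CC(=O)Oc1ccc(-c2ccc(F)cc2F)cc1C(=O)Nc1cc(C)ccc1C` is not yet measured. It differs from compound 2 as follows: 2,5-dimethylphenyl in place of benzyl on an amide-type nitrogen. The step from compound 2 to compound 3 is the one most like it, since both put a substituted phenyl directly on the amide-type nitrogen in place of benzyl, and that step stayed within the scatter. A small change downward or none beyond the scatter is therefore expected in this assay, with a number 3.6 percentage points lower from compound 2 to compound 4 (within the scatter) as the expected step. For compound 4 the estimate is 13%, expected to lie between 4% and 24%.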

Compound 4, a percentage reported as inhibition, in the whole organism at one dose (the size of the read-out at that dose, not a potency): 13.2%
Beside the measured number, compound 4's estimate is 0.2 percentage points below it; measured number inside the range.
By their numbers in this assay, from the lowest: compounds 3, 4 and 2 (each within the scatter of the next); then compound 1.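

With 2,5-dimethylphenyl on the amide-type nitrogen, this assay gives a number 3.4 percentage points lower from compound 2 to compound 4 (within the scatter) and a number 1.5 percentage points higher from compound 3 to compound 4 (within the scatter), so this third aromatic group cannot be told apart from benzyl or 2-chlorophenyl. The gap to the methyl amide remains, with a number 16.7 percentage points lower from compound 1 to compound 4 (beyond the scatter), and it now holds for a ring joined through a saturated carbon, a ring bearing chlorine and a ring bearing two methyl groups. Nothing available bears on why these compounds read as they do.

The compounds shown leave open whether the gap follows the aromatic ring itself or any group beyond methyl, which an ethyl, a longer alkyl chain or a cyclohexyl group on that nitrogen would help to separate. Going by these compounds, it also remains open how an unsubstituted phenyl or a pyridyl ring would read there.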